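Amide-side variation on the shared core, toward compound 4

The source may report more compounds than this note shows. Statements on the series, on what has been measured and on what is new or still open speak of the compounds shown alone.

Measured in an assay on cells for positive allosteric modulation of Cystic fibrosis transmembrane conductance regulator variant F508del (Homo sapiens), with stated times of 10 min and 7 s, in the presence of a further agent that is not named here; on this read-out higher numbers stand for an effect only at larger amounts of compound and lower numbers for an effect already at smaller amounts:
compound 1 `CC1(C)Cc2c(sc(NC(=O)c3cccnc3O)c2C(N)=O)C(C)(C)O1` gives 190 nM
compound 2 `CC1(C)Cc2c(sc(NC(=O)C(C)(C)CO)c2C(N)=O)C(C)(C)O1` gives 75 nM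
compound 3 `CC1(C)Cc2c(sc(NC(=O)[C@@H](O)C(C)(C)C)c2C(N)=O)C(C)(C)O1` gives 2.7 nM

Compound 3 holds the lowest number of the three. Its margin over compound 2 is a 28-fold lower number from compound 2 to compound 3 (1.44 log units; beyond the scatter), and over compound 1 a 70-fold lower number from compound 1 to compound 3 (1.85 log units; beyond the scatter); the remaining step, a 2.5-fold lower number from compound 1 to compound 2 (0.40 log units; beyond the scatter), is modest. All three steps come from exchanging the group on the carbonyl carbon whose other neighbour is the amide-type nitrogen, so this position is the one that has moved the read-out.

Compound 4, `Cc1n[nH]c(C(=O)Nc2sc3c(c2C(N)=O)CC(C)(C)OC3(C)C)c1Cl`, changes the same position: a group of 7 heavy atoms (4 carbon, 2 nitrogen, 1 chlorine; one five-membered aromatic ring with 2 hetero atoms) in place of a group of 6 heavy atoms (5 carbon, 1 oxygen; no ring), on a carbonyl carbon. Among the measured compounds shown here, the closest precedent is compound 1, the only measured compound with an aromatic ring on that carbonyl carbon, which stood far behind compound 3 by a 70-fold lower number from compound 1 to compound 3 (1.85 log units; beyond the scatter). A return to an aromatic ring is therefore expected to move the number up, though the ring here is different and the loss may be smaller. Compound 4 is estimated at 80 nM, range 15 nM to 500 nM, an expected step of a 30-fold higher number from compound 3 to compound 4 (1.47 log units; beyond the scatter).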

Compound 4, half-maximal effective concentration: 11 nM
Compound 4: the middle estimate sits 7.3-fold (0.86 log units) above what was measured; measured number below the stated range.
By their numbers in this assay, from the lowest: compound 3; then compound 4; then compound 2; then compound 1.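

An aromatic ring on this carbonyl carbon does not by itself hold the number high: exchanging one aromatic ring for another gives a 17-fold lower number from compound 1 to compound 4 (1.24 log units; beyond the scatter), so the identity of the ring matters at this position, not only its presence. The five-membered ring also improves on the 1-(hydroxymethyl)-1-methylethyl group, with a 6.8-fold lower number from compound 2 to compound 4 (0.83 log units; beyond the scatter), while the 1-hydroxy-2,2-dimethylpropyl group keeps the lowest number, with a 4.1-fold higher number from compound 3 to compound 4 (0.61 log units; beyond the scatter). No measurement at hand accounts for these differences.

The compounds shown do not separate what the chlorine, the methyl group and the ring nitrogens each contribute to the value of compound 4. Also open, going by these compounds, is how the read-out would respond to a nitrile or an amine in place of the chlorine.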